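The source may hold more compounds than are shown below. What is called first, only, known or untested is meant among the compounds shown, and "the series" means these compounds.

Compound 1, with the structure `Oc1cccc2[nH]c(-c3ccc(-c4ccc(-c5ccccc5)cc4)cc3)nc12`, was tested in a functional assay on HOP-62 cells (Homo sapiens) for inhibition, read by sulforhodamine B assay (a lower number here means a stronger inhibitor of growth, a higher number a weaker inhibitor of growth), and gave 9040 nM. Compound 2, with the structure `Oc1cccc2[nH]c(-c3ccc(-c4ccc(-c5ccc(F)cc5)cc4)cc3)nc12`, differs from compound 1 only by fluoro in place of hydrogen on an aromatic carbon; in this assay compound 2 gave 8310 nM. That single change produced a 1.1-fold lower number from compound 1 to compound 2 (0.04 log units; within the scatter). Compound 3, with the structure `Cc1ccc2[nH]c(-c3ccc(-c4ccc(-c5ccccc5)cc4)cc3)nc2c1`, carries a different core; how its core differs from that of compound 1 is not broken down here. In this assay compound 3 gave 39300 nM, the weakest growth inhibition of the three measured compounds, with gaps to compound 1 and compound 2 that lie beyond the usual scatter of such measurements.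

Compound 4, with the structure `Cc1ccc2[nH]c(-c3ccc(-c4ccc(-c5ccc(F)cc5)cc4)cc3)nc2c1`, has not yet been measured. It stands to compound 3 as compound 2 stands to compound 1: the difference is fluoro in place of hydrogen on an aromatic carbon, the same change in the same kind of place. Because the earlier example of this change gave a 1.1-fold lower number from compound 1 to compound 2 (0.04 log units; within the scatter), the expected step here is a 1.1-fold lower number from compound 3 to compound 4 (0.04 log units; within the scatter), a change too small to be told apart from the scatter. In this assay compound 4 is therefore estimated at 36000 nM, with a likely range from 18000 nM to 72000 nM.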

Compound 4, concentration for 50% growth inhibition: 33500 nM
Beside the measured number, compound 4's estimate is 1.1-fold (0.03 log units) above it; measured number inside the range.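

Putting fluoro in place of hydrogen, phenyl to 4-fluorophenyl, on the core of compound 3 gave a step too small to read in this assay, with a 1.2-fold lower number from compound 3 to compound 4 (0.07 log units; within the scatter). Set beside the same change on the core of compound 1, the two steps agree: the same change on two cores in this assay, a 1.1-fold lower number (0.04 log units; within the scatter) from compound 1 to compound 2 and a 1.2-fold lower number (0.07 log units; within the scatter) from compound 3 to compound 4, 1.1-fold (0.03 log units) apart, within the scatter of two such steps. This shows that, on these two cores, the change carried over as a step that stays inside the scatter, but it does not show that the change has no effect at all, as a small shift could be hidden there, and two cores cannot speak for the whole series.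

The compounds shown leave open whether another group in the same place, such as an amine, a methoxy group or a carboxylic acid, would give a step beyond the scatter. They also leave open whether fluoro would behave in the same way on any other core.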